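The source may hold more compounds than are shown below. What is called first, only, known or untested is meant among the compounds shown, and "the series" means these compounds.

Compound 2 `CC(C)(C)n1ncc(OCc2nnc(-c3ccc([N+](=O)[O-])cc3)o2)c(Cl)c1=O` is one of two close relatives measured in a functional assay on the whole organism for inhibition, with Mythimna separata as the target, with a stated time of 5 days; a higher number here means that more compound is needed for the effect, a lower number that less compound is needed. In this assay compound 2 gives > 300 ug/mL, which is a limit of the assay and not a number. Its partner is compound 1 `Cc1cc(C)cc(-c2nnc(COc3cnn(C(C)(C)C)c(=O)c3Cl)o2)c1`. In this assay compound 1 gives > 300 ug/mL, likewise a limit and not a number. The step that the two limits leave unreadable from compound 1 to compound 2 therefore has no readable size, and the limit of > 300 ug/mL in this assay, at which 2 of the 2 values shown sit, sums up all that the two measured values show. Compound 3 `CC(C)(C)n1ncc(OCc2nnc(-c3cc(F)c(Cl)cc3Cl)o2)c(Cl)c1=O` has not yet been measured. It differs from compound 2 by 2,4-dichloro-5-fluorophenyl in place of 4-nitrophenyl on an aromatic carbon. Going by the values given here, the only measured step that bears on this change is a step that the two limits leave unreadable from compound 1 to compound 2, which likewise exchanges one aryl group on the same carbon of the shared core, and it gives no readable size. With both known values sitting at the limit, no step beyond the scatter in this assay can be foreseen in either direction. Compound 3 is therefore expected to come out near 300 ug/mL, within 100 ug/mL to 1000 ug/mL. The estimated step of a number no higher from compound 2 to compound 3 (the limit leaves the size open) is expected to be none beyond the scatter, and most likely the assay will again report only a limit.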

Compound 3, half-maximal effective concentration: 23.1 ug/mL
Beside the measured number, compound 3's estimate is 13-fold (1.11 log units) above it; the whole stated range lies above it.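

The aryl group on an aromatic carbon of the five-membered aromatic ring with 2 nitrogen and 1 oxygen turns out to be a place where a single change can move the read-out in this assay, which the step between the two earlier compounds could not show, as that step cannot be read. Putting 2,4-dichloro-5-fluorophenyl in place of 4-nitrophenyl gives an at least 12-fold lower number from compound 2 to compound 3 (1.11 log units; beyond the scatter), and putting the same group in place of 3,5-dimethylphenyl gives an at least 12-fold lower number from compound 1 to compound 3 (1.11 log units; beyond the scatter). Both steps start from a limit of the assay and not a number, and compound 3 is the only one of the three with a measured number: the limit of > 300 ug/mL in this assay, at which 2 of the 3 values shown sit.

The entering group brings its fluorine and its 2 chlorine atoms together, so the compounds shown do not tell whether one of them alone carries the step, as a 4-chlorophenyl or a 4-fluorophenyl group in the same place could show. Going by these compounds, whether the aromatic ring itself is needed also stays open, and a cyclohexyl group or a pyridyl group at this carbon would bear on that.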